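A few compounds are considered here, and "the series" means these few. Any claim that something is new, unique, unknown or untested is made for them only; others in the source may bear on it.

Measured compounds:
- compound 1, `COc1cc(-n2cnc3ccc(-c4cccc(F)c4)cc32)cc(OC)c1OC`: 5270 nM
- compound 2, `COc1cc(-n2cnc3ccc(-c4ccc(C(F)(F)F)cc4)cc32)cc(OC)c1OC`: 3390 nM

In a functional assay on A549 cells (Homo sapiens) for antiproliferative activity, read by MTT assay, with a stated time of 72 h (on this read-out lower numbers stand for stronger inhibition and higher numbers for weaker inhibition), compound 1 gives 5270 nM, the highest of the two numbers; the nearest is compound 2, which reaches 3390 nM. Within the data shown here, the only measured step, a 1.6-fold lower number from compound 1 to compound 2 (0.19 log units; within the scatter), lies within the scatter and concerns a change of the same aryl ring that is varied here.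

Compound 3, `COc1cccc(-c2ccc3ncn(-c4cc(OC)c(OC)c(OC)c4)c3c2)c1`, is not yet measured. It differs from compound 1 as follows: methoxy in place of fluoro on an aromatic carbon.

The step from compound 1 to compound 2 is the only one that bears on this change, and it was within the scatter. Nothing else in the shown numbers points in either direction, so no step beyond the scatter is expected for compound 3 in this assay. The expected step is a 1.1-fold lower number from compound 1 to compound 3 (0.02 log units; within the scatter). For compound 3 the estimate is 5000 nM, with a range from 2000 nM to 13000 nM.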

Compound 3, half-maximal inhibitory concentration: 3180 nM
The estimate for compound 3 lay 1.6-fold (0.20 log units) above the measured number; the measured number falls inside the stated range.
By their numbers in this assay, from the lowest: compounds 3, 2 and 1 (each within the scatter of the next).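

In this assay, methoxy in place of fluoro on an aromatic carbon, meta to a large group, gives a 1.7-fold lower number from compound 1 to compound 3 (0.22 log units; within the scatter) and so stays within the scatter. This position therefore takes methoxy as well as fluoro without a step beyond the scatter. The exchange of 4-(trifluoromethyl)phenyl for 3-methoxyphenyl gives a 1.1-fold lower number from compound 2 to compound 3 (0.03 log units; within the scatter) and is also within the scatter, so the three aryl groups shown cannot be told apart in this assay, and no preference for one substituent or one ring position can be read.

Still open, from the compounds shown here alone, is whether a group of another kind on this ring, such as an amine or a carboxylic acid, would give a step beyond the scatter. Also open, going by these compounds, is how the unsubstituted phenyl compares. The data hold nothing that explains these numbers.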